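Shortening the phenoxy linker in a glutamate receptor series

The source may hold more compounds than are shown below. What is called first, only, known or untested is meant among the compounds shown, and "the series" means these compounds.

Of the compounds shown here, three sharing one core have been measured in an assay on isolated protein with metabotropic glutamate receptor 2 (Homo sapiens) as the target; on this read-out lower numbers stand for an effect already at smaller amounts and higher numbers for an effect only at larger amounts of compound. Compound 1 `CCS(=O)(=O)N(Cc1cccnc1)c1cccc(C(O)c2ccccc2)c1` gives 2500 nM. Compound 2 `CCS(=O)(=O)N(Cc1cccnc1)c1cccc(C(F)c2ccccc2)c1` gives 180 nM, and compound 3 `CCS(=O)(=O)N(Cc1cccnc1)c1cccc(COc2ccccc2)c1` gives 160 nM. Compound 3 has the lowest number of the three: the step of a 16-fold lower number from compound 1 to compound 3 (1.19 log units; beyond the scatter) is large, while the step of a 1.1-fold lower number from compound 2 to compound 3 (0.05 log units; within the scatter) stays within the scatter, so compound 2 and compound 3 cannot be told apart on this read-out.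

Compound 4 `CCS(=O)(=O)N(Cc1cccnc1)c1cccc(Oc2ccccc2)c1` differs from compound 3 in one place: phenoxy in place of phenoxymethyl on an aromatic carbon. Among the measured compounds shown here, no measured pair tests this change directly. The step of a 14-fold lower number from compound 1 to compound 2 (1.14 log units; beyond the scatter) and the step of a 16-fold lower number from compound 1 to compound 3 (1.19 log units; beyond the scatter) both show that this region of the molecule can move the number strongly, and the step of a 1.1-fold lower number from compound 2 to compound 3 (0.05 log units; within the scatter) shows that two different arrangements at the same position can give nearly the same result. Going by these compounds, removing the chain carbon is a change of a different kind, and its size is unknown from these data; a moderate rise in the number is expected, though a result within the scatter is possible. Compound 4 is therefore estimated at 400 nM, with a range from 120 nM to 1500 nM, which would mean a step of a 2.5-fold higher number from compound 3 to compound 4 (0.40 log units; beyond the scatter) in this assay.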

Compound 4, half-maximal effective concentration: 360 nM
For compound 4 the middle estimate is 1.1-fold (0.05 log units) above the measured one, within the range that was stated.
By their numbers in this assay, from the lowest: compounds 3, 2 and 4 (each within the scatter of the next, the first and the last beyond it); then compound 1.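

In this assay, among the compounds shown here, the step of a 2.3-fold higher number from compound 3 to compound 4 (0.35 log units; beyond the scatter) is the first direct test of the linker at this position, and it shows that removing the chain carbon from phenoxymethyl has a real but modest effect on the number. The step of a 2.0-fold higher number from compound 2 to compound 4 (0.30 log units; within the scatter) stays within the scatter, so the phenoxy compound cannot be separated from the fluoro compound on this read-out, while the step of a 6.9-fold lower number from compound 1 to compound 4 (0.84 log units; beyond the scatter) is modest and beyond the scatter, leaving the hydroxy compound with the highest number of the four. No measurement among these compounds offers an explanation for the effect of the shorter linker.

What the compounds shown leave open is whether a longer chain, such as phenoxyethyl, would continue the trend seen between phenoxy and phenoxymethyl, or whether an amine in place of the linking oxygen would keep the number near that of compound 4. Going by these compounds, it is also open whether the effect of linker length would hold with a chloro group or a methoxy group on the terminal aromatic ring.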